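Removing a Hydroxy Group from a Cinnamamide Anticonvulsant

This account rests on a few compounds, and the source may have more. Where it says the series, first, only, none or still open, it means among the compounds named here.

Three compounds have been measured in a functional assay on the whole organism (Hindlimb, strain albino) with Mus musculus as the target, in the maximal electroshock model, with a stated time of 0.5 h; on this read-out higher numbers stand for an effect only at larger amounts of compound and lower numbers for an effect already at smaller amounts:

compound 1, `COc1ccc(/C=C/C(=O)Nc2nc3ccccc3s2)cc1`, 435 umol/kg
compound 2, `O=C(/C=C/c1ccccc1)Nc1nc2ccc([N+](=O)[O-])cc2s1`, 485 umol/kg
compound 3, `COc1ccc(/C=C/C(=O)Nc2nc3ccc([N+](=O)[O-])cc3s2)cc1O`, 372 umol/kg

Compound 3 has the smallest of the three numbers, but its gap to compound 1 and its gap to compound 2 both lie within the usual scatter of this assay, so the three compounds cannot be told apart on these data. The account now turns to compound 4, `COc1ccc(/C=C/C(=O)Nc2nc3ccc([N+](=O)[O-])cc3s2)cc1`, which has not yet been measured. Compound 4 differs from compound 3 in one place: hydrogen in place of hydroxy on an aromatic carbon. Within the data shown here, no step between two measured compounds that differ in a single place is available, so the size of this change can only be guessed from the spread of the three numbers, which is narrow. Since the three measured compounds all sit within the scatter of one another in this assay, no step beyond the scatter is expected here, and the author estimates a 1.1-fold higher number from compound 3 to compound 4 (0.05 log units; within the scatter). For compound 4 the estimated value in this assay is 420 umol/kg, with a range from 240 umol/kg to 720 umol/kg.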

Compound 4, dose for half-maximal effect: 315 umol/kg
Compound 4: the middle estimate sits 1.3-fold (0.12 log units) above what was measured, within the range that was stated.
By their numbers in this assay, from the lowest: compounds 4, 3, 1 and 2 (each within the scatter of the next).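

In this assay the hydroxy on the aromatic carbon ortho to the methoxy group now has a step of its own: replacing it with hydrogen gives a 1.2-fold lower number from compound 3 to compound 4 (0.07 log units; within the scatter) and so shows that this position, in this one compound pair, tolerates the loss of the hydroxy without a change beyond the scatter. Among these compounds, the two other single changes leading to compound 4 can also be read for the first time, methoxy in place of hydrogen as a 1.5-fold lower number from compound 2 to compound 4 (0.19 log units; within the scatter) and nitro in place of hydrogen as a 1.4-fold lower number from compound 1 to compound 4 (0.14 log units; within the scatter), and neither step leaves the scatter either. No further data bear on this result.

The compounds shown leave open whether an amine, a carboxylic acid or a longer alkoxy chain on this aromatic carbon would move the number beyond the scatter. They also leave open whether hydrogen in place of hydroxy would give a similar step on a core without the nitro group.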